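A few compounds are considered here, and "the series" means these few. Any claim that something is new, unique, unknown or untested is made for them only; others in the source may bear on it.

Compound 3 `Nc1ncnc2c1c(-c1ccco1)cn2[C@H]1C[C@H](O)[C@@H](CO)O1` is the point of departure. In a toxicity assay on Huh-7 cells (Homo sapiens) for cytotoxicity, with a stated time of 3 days (on this read-out lower numbers stand for higher toxicity in this test and higher numbers for lower toxicity in this test), compound 3 gives > 44000 nM, which is a limit of the assay and not a number. Compound 1 `C[C@@]1(O)[C@H](O)[C@@H](CO)O[C@H]1n1cc(-c2cccc3ccccc23)c2c(N)ncnc21` also gives only a limit in this assay, namely > 44000 nM. For the measured compounds named here, compound 2 `C[C@@]1(O)[C@H](O)[C@@H](CO)O[C@H]1n1cc(-c2cc3ccccc3o2)c2c(N)ncnc21` is the one compound of the three with a measured number, giving 29400 nM in this assay. Going by the values given here, the single measured step between compounds differing in one place, an at least 1.4-fold lower number from compound 1 to compound 2 (0.17 log units; that floor lies within the scatter), comes from an exchange of one aromatic group for another on the shared core, and its floor lies within the usual scatter.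

Compound 4 `Nc1ncnc2c1c(-c1ccoc1)cn2[C@H]1C[C@H](O)[C@@H](CO)O1` differs from compound 3 by furan-3-yl in place of furan-2-yl on an aromatic carbon. The two structures have the same atoms, joined differently, and the exchange again sits on an aromatic carbon of the shared core. Among the compounds with values here, the only step that bears on such an exchange, an at least 1.4-fold lower number from compound 1 to compound 2 (0.17 log units; that floor lies within the scatter), was small, and two of the three values shown sit at the limit of > 44000 nM in this assay, at which 2 of the 3 values shown sit. The writer therefore expects no step beyond the scatter in this assay, with a step that the limit leaves unreadable from compound 3 to compound 4 as the expected outcome. Compound 4 is estimated at 60000 nM, between 30000 nM and 150000 nM, and is expected most likely to return a limit as well.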

Compound 4, half-maximal cytotoxic concentration: > 44000 nM
Compound 4: only a limit was reported; the forecaster's own chance of this, stated with the estimate: 75%; the middle value does not contradict the limit.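

Compound 3 and compound 4 both return only a limit in this assay, so no step can be read between them: the limit of > 44000 nM in this assay, at which 3 of the 4 values shown sit.

The compounds shown leave open whether furan-3-yl and furan-2-yl on this aromatic carbon differ at all in this assay, as neither compound has a measured number there.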